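The compounds below may be only part of what the source reports. "The series", "measured", "known", "first", "only" and "open" are said of these compounds alone.

Measured compounds:
Compound 1, `COc1cc(NCc2ccc(Cl)s2)ccc1-c1cnco1`: 53800 nM
Compound 2, `COc1cc(NCc2ccc(Br)s2)ccc1-c1cnco1`: 47300 nM

This account follows the step from compound 2 to compound 3. In an ADME assay on Vero cells (Chlorocebus sabaeus) for cytotoxicity, read by MTT assay, with a stated time of 96 h (on this read-out lower numbers stand for higher toxicity in this test and higher numbers for lower toxicity in this test), compound 2 gives 47300 nM, the lowest of the two numbers recorded; its nearest neighbour is compound 1 with 53800 nM, and the step of a 1.1-fold lower number from compound 1 to compound 2 (0.06 log units; within the scatter) is within the scatter, so the two compounds cannot be told apart on this read-out.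

Compound 3, `COc1cc(NCc2ccsc2)ccc1-c1cnco1`, has not yet been measured in this assay. It differs from compound 2 in one place: thiophen-3-yl in place of 5-bromothiophen-2-yl on a saturated chain carbon bound to a nitrogen on an aromatic ring.

Within the data shown here, only one measured step bears on this change, and only in part: a 1.1-fold lower number from compound 1 to compound 2 (0.06 log units; within the scatter) concerns the exchange of one halogen for another on the same ring, whereas here the halogen is removed and the ring is joined through a different carbon. That step was within the scatter. Among the measured compounds shown here, no measured pair shows the ring without a halogen. The step of a 1.2-fold higher number from compound 2 to compound 3 (0.07 log units; within the scatter) is therefore expected to lie within the scatter, with no clear direction. Compound 3 is estimated at 55000 nM, with a range from 25000 nM to 120000 nM.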

Compound 3, half-maximal cytotoxic concentration: 181000 nM
Compound 3: middle estimate off by 3.3-fold (0.52 log units), on the low side; measured number above the stated range.
By their numbers in this assay, from the lowest: compounds 2 and 1 (each within the scatter of the next); then compound 3.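

In this assay this position responds to a change that the exchange of one halogen for the other did not reveal: a 3.8-fold higher number from compound 2 to compound 3 (0.58 log units; beyond the scatter) and a 3.4-fold higher number from compound 1 to compound 3 (0.53 log units; beyond the scatter) both lie beyond the scatter and both point to a higher number, which here stands for lower toxicity in this test. The group on the saturated chain carbon bound to a nitrogen on an aromatic ring therefore matters to this read-out, although the steps are modest, and thiophen-3-yl departs from both halogenated groups in two ways at once, since the halogen is gone and the ring is joined through a different carbon. Nothing available explains the rise.

The three compounds cannot separate these two differences: a thiophen-2-yl group without a halogen would show whether losing the halogen alone gives the higher number or whether the point of attachment is also involved. On these data alone, how a phenyl ring or a 5-methylthiophen-2-yl group would read at the same place also remains open.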